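Swapping the amide for a urea in a weak phospholipase series

This account rests on a few compounds, and the source may have more. Where it says the series, first, only, none or still open, it means among the compounds named here.

Three biaryl ethers carrying an ethoxy group on one ring have been tested in an assay on COS-7 cells for inhibition of patatin-like phospholipase domain-containing protein 2 (Mus musculus); a lower number here means a stronger inhibitor, a higher number a weaker inhibitor. Compound 1, `CCOc1ccc(-c2cccc(S(=O)(=O)NC)c2)cc1`, gives 200000 nM. Compound 2, `CCOc1ccc(-c2cccc(C(=O)N3CCCC3)c2)cc1`, gives 160000 nM. Compound 3, `CCNC(=O)c1cccc(-c2ccc(OCC)cc2)c1`, gives 90000 nM, the lowest of the three numbers, but its step to compound 2, a 1.8-fold lower number from compound 2 to compound 3 (0.25 log units; within the scatter), stays within the scatter, while its step from compound 1, a 2.2-fold lower number from compound 1 to compound 3 (0.35 log units; beyond the scatter), is modest yet beyond it. The remaining step, a 1.3-fold lower number from compound 1 to compound 2 (0.10 log units; within the scatter), is likewise within the scatter. All three substituents on the second ring thus leave the numbers in the same weak region.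

Compound 4, `CCOc1ccc(-c2cccc(NC(=O)N(C)C)c2)cc1`, continues this variation: (dimethylcarbamoyl)amino in place of ethylcarbamoyl on an aromatic carbon. The three measured steps all change the same position and none exceeded a modest size, so the urea is expected to behave like its neighbours rather than to open a new range. Compound 4 is therefore estimated at 100000 nM in this assay, with a range from 40000 nM to 250000 nM, which corresponds to an expected step of a 1.1-fold higher number from compound 3 to compound 4 (0.05 log units; within the scatter) and no movement clearly beyond the scatter relative to compound 3.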

Compound 4, half-maximal inhibitory concentration: 70000 nM
Compound 4: the middle estimate sits 1.4-fold (0.15 log units) above what was measured; the measured number falls inside the stated range.
By their numbers in this assay, from the lowest: compounds 4, 3, 2 and 1 (each within the scatter of the next, the first and the last beyond it).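

The urea fits at this aromatic carbon without a readable change from the amide: in this assay the exchange of ethylcarbamoyl for (dimethylcarbamoyl)amino gives a 1.3-fold lower number from compound 3 to compound 4 (0.11 log units; within the scatter) and so cannot be told apart from compound 3, even though the ring carbon now carries the nitrogen rather than the carbonyl. What is new lies in the comparison with the other two groups, where a 2.3-fold lower number from compound 2 to compound 4 (0.36 log units; beyond the scatter) and a 2.9-fold lower number from compound 1 to compound 4 (0.46 log units; beyond the scatter) are both modest but beyond the scatter; compound 3 separated in this way only from compound 1, whereas compound 4 separates from compound 2 as well, and all four numbers still remain in the same weak region. No other measurement accompanies these numbers that would account for the small differences among the four groups.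

The compounds shown leave open whether a carboxylic acid or a primary amine on this same aromatic carbon would move the number out of that weak region, or whether a urea closed into a pyrrolidine ring would track compound 4. They also leave open what a longer chain would do in place of the ethoxy group, which all four compounds carry.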